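The source may hold more compounds than are shown below. What is called first, only, known or untested is meant among the compounds shown, and "the series" means these compounds.

Measured so far:
- compound 1, `COc1ccc(OC)c(/C=N/NC(=O)Nc2ccc(Oc3ccnc(-c4nncn4CCN(C)C)c3)c(F)c2)c1`: 6400 nM
- compound 2, `CN(C)CCn1cnnc1-c1cc(Oc2ccc(NC(=O)N/N=C/c3ccccc3O[N+](=O)[O-])cc2F)ccn1`: 7150 nM
- compound 3, `COc1cc(/C=N/NC(=O)Nc2ccc(Oc3ccnc(-c4nncn4CCN(C)C)c3)c(F)c2)cc(OC)c1OC`: 22500 nM

These three compounds were tested in a functional assay on U-87MG ATCC cells (Homo sapiens) for cytotoxicity, read by MTT assay, with a stated time of 72 h; a higher number here means a weaker inhibitor, a lower number a stronger inhibitor. Compound 1 gives the lowest number of the three, though compound 2 sits within the scatter of it, so the two cannot be ranked against each other; compound 3 stands clearly apart, with a 3.5-fold higher number from compound 1 to compound 3 (0.55 log units; beyond the scatter).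

Compound 4 is `COc1ccc(/C=N/NC(=O)Nc2ccc(Oc3ccnc(-c4nncn4CCN(C)C)c3)c(F)c2)cc1O`. It keeps the shared core of compound 1 and changes only the aromatic ring that hangs from the carbon with a double bond to nitrogen:

3-hydroxy-4-methoxyphenyl in place of 2,5-dimethoxyphenyl on a carbon with a double bond to nitrogen

The measured steps that bear on this are the ones that also swap that ring. The step of a 1.1-fold higher number from compound 1 to compound 2 (0.05 log units; within the scatter) shows that one exchange at this position left the number essentially unchanged, while a 3.5-fold higher number from compound 1 to compound 3 (0.55 log units; beyond the scatter) shows a modest weakening when three methoxy groups were placed there. Compound 4 carries two oxygen substituents, as compound 1 does, so a step close to the scatter or a small weakening seems the most likely outcome, and no large move in either direction is expected.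

The estimate for compound 4 is therefore 9000 nM, with a range of 4000 nM to 22000 nM, which corresponds to an expected step of a 1.4-fold higher number from compound 1 to compound 4 (0.15 log units; within the scatter).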

Compound 4, half-maximal inhibitory concentration: > 100000 nM
Compound 4: only a limit was reported; the forecaster's own chance of this, stated with the estimate: 10%; middle value at least 11-fold (1.04 log units) from the limit.
By their numbers in this assay, from the lowest: compounds 1 and 2 (each within the scatter of the next); then compound 3. At a limit, above all of these: compound 4.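

In this assay compound 4 is reported only as a limit: the limit of > 100000 nM in this assay, at which 1 of the 4 values shown sits.

The earlier compounds shown here showed this aromatic ring, on the carbon with a double bond to nitrogen, giving steps no larger than modest, whereas the new steps reach further, with an at least 15-fold higher number from compound 1 to compound 4 (1.19 log units; beyond the scatter), an at least 13-fold higher number from compound 2 to compound 4 (1.14 log units; beyond the scatter) and an at least 4.4-fold higher number from compound 3 to compound 4 (0.64 log units; beyond the scatter). Both 2,5-dimethoxyphenyl and 3-hydroxy-4-methoxyphenyl carry two oxygen atoms, yet the first of these steps is large, so the oxygen count on this ring does not alone set the number, and the entering group also brings a hydrogen-bond donor where the leaving group has none.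

Compound 4 differs from compound 1 both in having a hydroxy group and in where its oxygen groups stand on the ring, and the compounds shown do not separate these two changes. From the compounds shown here alone, it remains open whether a 3,4-dimethoxyphenyl group or a 3-amino-4-methoxyphenyl group at this place would give a number close to that of compound 1 or one as far out as the limit of compound 4.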